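From Diethylamino to Pyrrolidin-1-yl in Compound 2

This account rests on a few compounds, and the source may have more. Where it says the series, first, only, none or still open, it means among the compounds named here.

Of the compounds shown here, three have been tested in a functional assay on HepG2 cells (Homo sapiens) for antiproliferative activity, read by MTT assay, with a stated time of 48 h; a lower number here means a stronger inhibitor, a higher number a weaker inhibitor. Compound 1 `COc1cc2oc(-c3ccccc3)cc(=O)c2c2c1OCCCCO2` gives > 100000 nM, which is a limit of the assay and not a number. Compound 2 `CCN(CC)CCCCOc1c(OC)cc2oc(-c3ccccc3)cc(=O)c2c1O` gives 7100 nM. Compound 3 `CN(C)CCCOc1c(OCc2ccccc2)cc2oc(-c3ccccc3)cc(=O)c2c1O` gives 2200 nM. Of these two actual numbers, compound 2 has the higher, making it the weaker inhibitor of the pair, and the gap lies beyond the usual scatter of repeated measurements.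

Compound 4 `COc1cc2oc(-c3ccccc3)cc(=O)c2c(O)c1OCCCCN1CCCC1` has not yet been measured. It differs from compound 2 in one place, where pyrrolidin-1-yl stands in place of diethylamino on a saturated chain carbon, four bonds along the chain from an oxygen on an aromatic ring: pyrrolidin-1-yl in place of diethylamino on a saturated chain carbon, four bonds along the chain from an oxygen on an aromatic ring. Among the measured compounds shown here, no tested pair shows this swap on its own. The best guide is therefore compound 2 at 7100 nM. The estimated step is small, a 1.2-fold lower number from compound 2 to compound 4 (0.07 log units; within the scatter), and is expected to stay within the scatter. For compound 4 the expected value is 6000 nM, with an estimated range of 2500 nM to 15000 nM.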

Compound 4, half-maximal inhibitory concentration: 4900 nM
Estimate against measurement, compound 4: 1.2-fold (0.09 log units) above, within the range that was stated.
By their numbers in this assay, from the lowest: compound 3; then compounds 4 and 2 (each within the scatter of the next). At a limit, above all of these: compound 1.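

In this assay, pyrrolidin-1-yl in place of diethylamino gives a 1.4-fold lower number from compound 2 to compound 4 (0.16 log units; within the scatter) and so leaves the reading where it was, within the usual scatter. Among the compounds shown here, this is the first direct view of this position: on a saturated chain carbon, four bonds along the chain from an oxygen on an aromatic ring, the amine can be tied into a five-membered non-aromatic ring or left open with no measurable effect on the number. Nothing measured here accounts for why the two groups read alike.

On these data alone, whether a six-membered ring such as piperidin-1-yl or morpholin-4-yl would also hold the number at this place remains open. So does the effect of a shorter or longer chain carrying the same pyrrolidin-1-yl.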